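Methyl to Chloro: Expected Change in Cytotoxicity

The source may hold more compounds than are shown below. What is called first, only, known or untested is meant among the compounds shown, and "the series" means these compounds.

Measured in a functional assay on L1210 cells (Mus musculus) for cytotoxicity, with a stated time of 48 h; a lower number here means a stronger inhibitor, a higher number a weaker inhibitor:
compound 1 `Cc1ccc(/C=C2\CCC/C(=C\c3cccc([N+](=O)[O-])c3)C2=O)cc1` gives 41800 nM
compound 2 `O=C1/C(=C/c2ccc(F)cc2)CCC/C1=C\c1ccccc1[N+](=O)[O-]` gives 8400 nM

Compound 1 stands at the higher of the two numbers; compound 2 gives a lower number, and that gap lies beyond the usual scatter. Compound 3 `O=C1/C(=C/c2ccc(Cl)cc2)CCC/C1=C\c1cccc([N+](=O)[O-])c1` has not yet been measured in this assay. It differs from compound 1 by chloro in place of methyl on an aromatic carbon. No step of this kind is shown among the measured compounds, so the expectation rests on compound 1 alone. A swap of one small group for another is expected to give at most a modest step, with no clear direction. For compound 3 the estimate is 30000 nM, with a range from 9000 nM to 90000 nM, meaning an expected step of a 1.4-fold lower number from compound 1 to compound 3 (0.14 log units; within the scatter).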

Compound 3, half-maximal inhibitory concentration: 9160 nM
Beside the measured number, compound 3's estimate is 3.3-fold (0.52 log units) above it; measured number inside the range.
By their numbers in this assay, from the lowest: compounds 2 and 3 (each within the scatter of the next); then compound 1.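

In this assay, changing 4-methylphenyl to 4-chlorophenyl gives a 4.6-fold lower number from compound 1 to compound 3 (0.66 log units; beyond the scatter), so exchanging a single atom at this spot, para to a large group, moves the number by more than the usual scatter. Going by these compounds alone, this is the first direct view of a change at this position, and here chloro gives the lower number. Nothing available here explains why.

Still open, on these data alone, is whether a methoxy group or an amine at this position would lower the number further or raise it, and whether the same swap would have a similar effect on a different core.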